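Moving the hydroxyl group on a furan carbohydrazide series

The source may report more compounds than this note shows. Statements on the series, on what has been measured and on what is new or still open speak of the compounds shown alone.

Of the compounds shown here, three built around a shared furan carbohydrazide core have been tested in a functional assay on BGC-823 cells (Homo sapiens) for inhibition, read by sulforhodamine B assay, with a stated time of 48 h, tested at 10 uM; on this read-out higher numbers stand for more inhibition of growth at the one concentration tested and lower numbers for less inhibition of growth. Compound 1 `O=C(N/N=C/c1ccccc1O)c1ccc(-c2ccc(F)cc2)o1` gives 74%, the highest of the three numbers. Compound 3 `O=C(N/N=C/c1ccc(-c2ccccc2F)o1)c1ccc(Cl)cc1`, the nearest to it, gives 31.5%, a number that lies beyond the scatter below compound 1. Compound 2 `O=C(N/N=C/c1ccc(-c2ccc(Cl)cc2)o1)c1ccccc1`, the furthest, gives 19.4%, also beyond the scatter below compound 1. Both of these weaker compounds carry the aryl-furan unit on the other side of the hydrazone linkage than compound 1 does, so no single-change comparison among the measured compounds exists.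

Compound 4 `O=C(N/N=C/c1ccc(O)cc1)c1ccc(-c2ccc(F)cc2)o1` has not been measured in this assay. It differs from compound 1 in one place: 4-hydroxyphenyl in place of 2-hydroxyphenyl on a carbon with a double bond to nitrogen. The two compounds contain the same atoms joined differently, so only the placement of the hydroxyl on the phenyl ring changes.

Within the data shown here, with no measured pair showing what such a move does, the expectation rests on compound 1 alone. Because compound 1 gives 74%, compound 4 is expected to stay active. The step expected here is a number 26 percentage points lower from compound 1 to compound 4 (beyond the scatter), a drop beyond the scatter rather than a rise. Compound 4 is estimated at 48%, within a range from 15% to 78%.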

Compound 4, percent growth inhibition at one concentration: 46.3%
The estimate for compound 4 lay 1.7 percentage points above the measured number, and the stated range covers the measured number.
By their numbers in this assay, from the lowest: compound 2; then compound 3; then compound 4; then compound 1.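

Among these compounds, this is the first comparison that changes one thing only: the hydroxyl moves on the phenyl ring, and in this assay the step is a number 27.7 percentage points lower from compound 1 to compound 4 (beyond the scatter), beyond the usual scatter of repeated measurements. The placement of the hydroxyl therefore matters here, even though 2-hydroxyphenyl and 4-hydroxyphenyl have the same heavy atoms and the same counts of hydrogen-bond donors and acceptors, and compound 4 still gives 46.3%, so the move lowers growth inhibition without abolishing it. Nothing available accounts for the difference between the two placements.

What the compounds shown leave open is whether the hydroxyl itself is needed at all, which a methoxy group, an amine or a carboxylic acid on the same phenyl ring could help to test. On these data alone, it also remains open whether moving the hydroxyl would give a similar step with another group in place of the 4-fluorophenyl unit, or with the aryl-furan unit on the other side of the hydrazone linkage, as in compound 2 and compound 3.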